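Branching the Ester Tail of a Retinoid Amide

A few compounds are considered here, and "the series" means these few. Any claim that something is new, unique, unknown or untested is made for them only; others in the source may bear on it.

Compound 1, `Cc1cc2c(cc1C(=O)c1ccc(C(=O)NCCCCCCNC(=O)c3ccc(C(=O)Nc4ccc5c(c4)C(C)(C)CCC5(C)C)cc3)cc1)C(C)(C)CCC2(C)C`, gives > 1000000 nM in a functional assay on NB-4 cells (Homo sapiens) for inhibition, read by MTT assay, with a stated time of 48 h; a higher number here means a weaker inhibitor, a lower number a stronger inhibitor; this is a limit of the assay, not a number.
Compound 2, `C=C(c1ccc(C(=O)OCCOC(=O)c2ccc(C(=O)Nc3ccc4c(c3)C(C)(C)CCC4(C)C)cc2)cc1)c1cc2c(cc1C)C(C)(C)CCC2(C)C`, gives > 1000000 nM in this assay; this too is a limit of the assay.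
Compound 3, `CCCC(=O)OCCOC(=O)c1ccc(C(=O)Nc2ccc3c(c2)C(C)(C)CCC3(C)C)cc1`, gives 11000 nM in this assay.

Among the compounds with values here, compound 3 is the only compound with a measured number. The other two results sit at the limit of > 1000000 nM in this assay, at which 2 of the 3 values shown sit.

Compound 4, `CCCC(CCC)C(=O)OCCOC(=O)c1ccc(C(=O)Nc2ccc3c(c2)C(C)(C)CCC3(C)C)cc1`, differs from compound 3 in one place: 1-propylbutyl in place of propyl on a carbonyl carbon. Within the data shown here, no measured pair shows what such a change does here. Putting 1-propylbutyl in place of propyl is expected to shift the value only slightly, within the scatter, so the step from compound 3 to compound 4 is estimated at a 1.4-fold higher number from compound 3 to compound 4 (0.13 log units; within the scatter). Compound 4 is expected to give about 15000 nM, within 4000 nM to 60000 nM.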

Compound 4, half-maximal inhibitory concentration: > 1000000 nM
Compound 4 was reported as a limit (the forecaster's own chance of this, stated with the estimate: 10%); at least 66-fold (1.82 log units) between middle value and limit.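

Compound 3 alone could not show how sensitive this position is. Putting 1-propylbutyl in place of propyl on the carbonyl carbon gives, in this assay, an at least 90-fold higher number from compound 3 to compound 4 (1.95 log units; beyond the scatter), so a change of carbon atoms alone at this position is enough to produce a large step. The result for compound 4 is a limit, not a number: the limit of > 1000000 nM in this assay, at which 3 of the 4 values shown sit.

Going by these compounds, what a straight heptyl chain or an amine at this position would give remains open. The compounds shown therefore do not separate the effect of branching from that of chain length.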